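Thienopyrimidine ether pyridazinone amides: cytotoxicity notes

The compounds below may be only part of what the source reports. "The series", "measured", "known", "first", "only" and "open" are said of these compounds alone.

Measured so far:
- compound 1, `Cc1cc(=O)n(-c2ccc(F)cc2)nc1C(=O)Nc1ccc(Oc2ncnc3sccc23)cc1`: 6460 nM
- compound 2, `Cc1ccc(-n2nc(C(=O)Nc3ccc(Oc4ncnc5sccc45)c(F)c3)c(C)cc2=O)cc1`: > 40000 nM

In a functional assay on HepG2 cells (Homo sapiens) for cytotoxicity, read by MTT assay, with a stated time of 72 h (a higher number here means a weaker inhibitor, a lower number a stronger inhibitor), compound 1 gives 6460 nM. For compound 2 the result is only a limit, > 40000 nM, so no number is known for it; this is the limit of > 40000 nM in this assay, at which 1 of the 2 values shown sits. For the measured compounds named here, of the two values shown, compound 1 therefore carries the only measured number, and compound 2 stands at the limit.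

Compound 3, `Cc1cc(=O)n(-c2ccc(F)cc2)nc1C(=O)Nc1ccc(Oc2ncnc3sccc23)c(F)c1`, has not been measured. It differs from compound 2 by fluoro in place of methyl on an aromatic carbon. Going by the values given here, no step between measured compounds is available to guide this change. The step from compound 2 to compound 3 is expected to run toward stronger inhibition, an at least 2.0-fold lower number from compound 2 to compound 3 (0.30 log units; that floor lies within the scatter), its size uncertain since compound 2 is a limit. Compound 3 is estimated at 20000 nM, with a range of 5000 nM to 80000 nM.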

Compound 3, half-maximal inhibitory concentration: 12500 nM
Estimate against measurement, compound 3: 1.6-fold (0.20 log units) above, within the range that was stated.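

In this assay, the change from 4-methylphenyl to 4-fluorophenyl brings an at least 3.2-fold lower number from compound 2 to compound 3 (0.50 log units; beyond the scatter), which shows that the number responds to the group at this place, para to a large group. Compound 2 is a limit, so this step has a floor and no fixed size: the limit of > 40000 nM in this assay, at which 1 of the 3 values shown sits. Fluoro in place of hydrogen on an aromatic carbon gives a 1.9-fold higher number from compound 1 to compound 3 (0.29 log units; within the scatter), so compound 1 and compound 3 are not separated by that change.

On these data alone, how a chloro, a methoxy or an amine at the para place would read in this assay stays open, as does any trend across such groups. As far as these compounds go, the true number for compound 2 also stays open, so the full size of the step from methyl to fluoro remains unknown.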